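A few compounds are considered here, and "the series" means these few. Any claim that something is new, unique, unknown or untested is made for them only; others in the source may bear on it.

Series notes on a functional assay (Pituitary gland cell) with Rattus norvegicus as the target; on this read-out lower numbers stand for an effect already at smaller amounts and higher numbers for an effect only at larger amounts of compound. Compound 1 `CC(C)(N)CC(=O)N[C@@H]1CCc2ccccc2N(Cc2ccc(-c3ccccc3C(=O)NCc3ccc(O)cc3)cc2)C1=O` gives 0.3 uM in this assay. Compound 2 `CC(C)(N)CC(=O)N[C@@H]1CCc2ccccc2N(Cc2ccc(-c3ccccc3C(=O)NCCO)cc2)C1=O` gives 3 uM in this assay, and compound 3 `CC(C)(N)CC(=O)N[C@@H]1CCc2ccccc2N(Cc2ccc(-c3ccccc3C(=O)NCCCO)cc2)C1=O` gives 0.4 uM in this assay. On these three numbers compound 3 stands second highest: it sits within the scatter of compound 1 (a 1.3-fold higher number from compound 1 to compound 3 (0.12 log units; within the scatter)) and beyond the scatter from compound 2 (a 7.5-fold lower number from compound 2 to compound 3 (0.88 log units; beyond the scatter)).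

The next member, compound 4 `CCCCCNC(=O)c1ccccc1-c1ccc(CN2C(=O)[C@H](NC(=O)CC(C)(C)N)CCc3ccccc32)cc1`, differs from compound 3 by ethyl in place of hydroxy on a saturated chain carbon, three bonds along the chain from an amide-type nitrogen. Going by the values given here, no measured step covers this change directly: every measured compound keeps a hydroxy, and the two steps beyond the scatter, a 10-fold higher number from compound 1 to compound 2 (1.00 log units; beyond the scatter) and a 7.5-fold lower number from compound 2 to compound 3 (0.88 log units; beyond the scatter), only exchange one hydroxy-bearing group for another. As far as these compounds go, the second of these shows that a longer chain on the amide nitrogen can go with a lower number, but the contribution of the hydroxy itself is untested here. The expected step in this assay is a 2.0-fold higher number from compound 3 to compound 4 (0.30 log units; within the scatter), a modest move toward a higher number with wide uncertainty. Compound 4 is therefore estimated at 0.8 uM in this assay, with a range from 0.2 uM to 3 uM.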

Compound 4, concentration for half-maximal effect: > 1 uM
Compound 4 ended at the assay's limit; the forecaster's own chance of this, stated with the estimate: 5%; middle value at least 1.2-fold (0.09 log units) from the limit.
By their numbers in this assay, from the lowest: compounds 1 and 3 (each within the scatter of the next); then compound 2.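

In this assay the result for compound 4 is a limit of the assay and not a number: the limit of > 1 uM in this assay, at which 1 of the 4 values shown sits. Even so, it gives the first read on losing the hydroxy at this place, on a saturated chain carbon, three bonds along the chain from an amide-type nitrogen: 3-hydroxypropyl to pentyl is an at least 2.5-fold higher number from compound 3 to compound 4 (0.39 log units; beyond the scatter), and the exchange of 4-hydroxyphenyl for butyl at the carbon bound to the amide-type nitrogen is an at least 3.3-fold higher number from compound 1 to compound 4 (0.52 log units; beyond the scatter). So chain length alone does not carry the low numbers of compound 1 and compound 3, while the step from compound 2 cannot be read.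

As far as these compounds go, the full size of both readable steps stays open. From the compounds shown here alone, whether the hydroxy can be replaced at all also stays open: an amine or a carboxylic acid in its place on the same chain would test this.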